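The source may report more compounds than this note shows. Statements on the series, on what has been measured and on what is new or still open speak of the compounds shown alone.

Measured compounds:
compound 1 `O=C(Nc1cccc(-n2cc(-c3ccncc3)c(-c3cc(O)cc(Cl)c3)n2)c1)Nc1ccc(Cl)c(C(F)(F)F)c1` gives 90% in a functional assay on SK-MEL-5 cells (Homo sapiens) for inhibition, read by sulforhodamine B assay, with a stated time of 48 h, tested at 1 uM; a lower number here means a stronger effect, a higher number a weaker effect of the compound at the concentration tested
compound 2 `O=C(Nc1cccc(-n2cc(-c3ccncc3)c(-c3cc(O)cc(Cl)c3)n2)c1)Nc1ccc(Cl)c(Cl)c1` gives 86% in this assay
compound 3 `COc1cc(Cl)cc(-c2nn(-c3cccc(NC(=O)Nc4ccc(Cl)c(C(F)(F)F)c4)c3)cc2-c2ccncc2)c1` gives 83% in this assay

Compound 3 gives the lowest of the three numbers, but its distance to compound 2 and to compound 1 is in each case within the scatter, so the three measured compounds cannot be told apart on these values. The two single steps seen so far are small: a number 4 percentage points lower from compound 1 to compound 2 (within the scatter) and a number 7 percentage points lower from compound 1 to compound 3 (within the scatter).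

Compound 4 `COc1cc(Cl)cc(-c2nn(-c3cccc(NC(=O)Nc4ccc(Cl)c(Cl)c4)c3)cc2-c2ccncc2)c1` has not yet been measured. It differs from compound 3 by chloro in place of trifluoromethyl on an aromatic carbon. The same change has already been made once, from compound 1 to compound 2, where it gave a number 4 percentage points lower from compound 1 to compound 2 (within the scatter). On that basis the step from compound 3 to compound 4 is expected to stay within the scatter as well, with at most a slight drift to a lower number, estimated as a number 3 percentage points lower from compound 3 to compound 4 (within the scatter). Compound 4 is therefore expected to give about 80% in this assay, within a range from 68% to 92%.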

Compound 4, a percentage reported as activity, at one concentration (the size of the read-out at that concentration, not a potency): 88%
Compound 4: middle estimate off by 8 percentage points, on the low side; low and high end bracket the measured number.
By their numbers in this assay, from the lowest: compounds 3, 2, 4 and 1 (each within the scatter of the next).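

On a second core, chloro in place of trifluoromethyl gives a number 5 percentage points higher from compound 3 to compound 4 (within the scatter), so in this assay this change shows no direction that can be read: the same change on two cores in this assay, a number 4 percentage points lower (within the scatter) from compound 1 to compound 2 and a number 5 percentage points higher (within the scatter) from compound 3 to compound 4, 9 percentage points apart, within the scatter of two such steps. Methyl in place of hydrogen on the oxygen can now also be read a second time, as a number 2 percentage points higher from compound 2 to compound 4 (within the scatter), and it too shows no direction that holds across both cores: the same change on two cores in this assay, a number 7 percentage points lower (within the scatter) from compound 1 to compound 3 and a number 2 percentage points higher (within the scatter) from compound 2 to compound 4, 9 percentage points apart, within the scatter of two such steps. Each of the two changes has now been read twice, and all four steps lie within the scatter, so neither place has yet shown a change that moves the number in this assay.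

As far as these compounds go, whether an amine or a carboxylic acid at the place of the trifluoromethyl group, or a longer chain on the oxygen, would give a step beyond the scatter remains open. From the compounds shown here alone, these read-outs give the size of the effect of all four compounds at the one concentration tested, and whether any of them has a stronger or weaker effect at other concentrations remains open.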